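Ester branching and ring substituent on mouse microsome stability

The compounds below may be only part of what the source reports. "The series", "measured", "known", "first", "only" and "open" are said of these compounds alone.

Measured so far:
Compound 1, `CCCCOC(=O)Cc1c(C(C)C)nc(CCCC)n(Cc2ccc(-c3ccccc3-c3noc(=O)[nH]3)cc2)c1=O`: in an ADME assay on microsomes from liver (Mus musculus) for metabolic stability, with a stated time of 30 min (on this read-out lower numbers stand for a less stable compound and higher numbers for a more stable compound), compound 1 gives 21.6%.
Compound 2, `CCCCc1nc(C(C)C)c(CC(=O)OCC(C)C)c(=O)n1Cc1ccc(-c2ccccc2-c2noc(=O)[nH]2)cc1`: compound 2 gives 13.7%.
Compound 3, `CCCCOC(=O)Cc1c(C)nc(CCCC)n(Cc2ccc(-c3ccccc3-c3noc(=O)[nH]3)cc2)c1=O`: compound 3 gives 10.2%.

Compound 2 differs from compound 1 by isopropyl in place of propyl on a saturated chain carbon bound to an oxygen next to a carbonyl group. The step in this assay is a number 7.9 percentage points lower from compound 1 to compound 2 (within the scatter). Compound 3 differs from compound 1 by methyl in place of isopropyl on an aromatic carbon, and here the step is a number 11.4 percentage points lower from compound 1 to compound 3 (beyond the scatter). Compound 3 thus holds the lowest of the three numbers, though compound 2 stands within the scatter of it; only compound 1 lies beyond.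

Compound 4, `CCCCc1nc(C)c(CC(=O)OCC(C)C)c(=O)n1Cc1ccc(-c2ccccc2-c2noc(=O)[nH]2)cc1`, is not yet measured in this assay. Relative to compound 3 it carries isopropyl in place of propyl on a saturated chain carbon bound to an oxygen next to a carbonyl group. This is the same change as that from compound 1 to compound 2, made on the same place, here on the core of compound 3 instead of the core of compound 1; how those two cores differ is set out above.

Among the compounds with values here, the single measured instance of this change, a number 7.9 percentage points lower from compound 1 to compound 2 (within the scatter), was within the scatter, and compound 3 already sits at a low number, 10.2%, so a step of similar direction and similar or smaller size is expected, a number 5.2 percentage points lower from compound 3 to compound 4 (within the scatter). Compound 4 is accordingly estimated at 5%. For compound 4 the range is expected to run from 1% to 14%.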

Compound 4, percent of the compound remaining: 7.7%
Estimate against measurement, compound 4: 2.7 percentage points below, and the stated range covers the measured number.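

In this assay, isopropyl in place of propyl on a saturated chain carbon bound to an oxygen next to a carbonyl group gives a number 2.5 percentage points lower from compound 3 to compound 4 (within the scatter), and the two steps for this change cannot be told apart: the same change on two cores in this assay, a number 7.9 percentage points lower (within the scatter) from compound 1 to compound 2 and a number 2.5 percentage points lower (within the scatter) from compound 3 to compound 4, 5.4 percentage points apart, within the scatter of two such steps. Methyl in place of isopropyl on an aromatic carbon gives a number 6 percentage points lower from compound 2 to compound 4 (within the scatter), and here too the gap between the two steps stays inside the scatter, even though only one of the steps lies beyond it: the same change on two cores in this assay, a number 11.4 percentage points lower (beyond the scatter) from compound 1 to compound 3 and a number 6 percentage points lower (within the scatter) from compound 2 to compound 4, 5.4 percentage points apart, within the scatter of two such steps. Both changes therefore carry from one core to the other without a detectable difference, but this rests on a single pair of cores, does not show that the steps are equal in size, and does not establish that the ester change has any effect of its own, as both of its steps lie within the scatter.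

From the compounds shown here alone, all four compounds carry a butoxycarbonyl or isobutoxycarbonyl group, so it remains open how this read-out would respond to a carboxylic acid or an amide in that place. Also open, going by these compounds, is whether an ethyl group on the aromatic carbon would read closer to methyl or to isopropyl, and what a longer chain in place of the butyl would do.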